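Benzyloxyanilino series: nitro replacing hydrogen on the benzyl ring

The source may report more compounds than this note shows. Statements on the series, on what has been measured and on what is new or still open speak of the compounds shown alone.

Measured so far:
- compound 1 `c1ccc(COc2ccc(Nc3ncnc4cc5c(cc34)OCCOCCOCCO5)cc2)cc1`: 23900 nM
- compound 2 `FC(F)(F)c1ccc(COc2cccc(Nc3ncnc4cc5c(cc34)OCCOCCOCCO5)c2)cc1`: 20000 nM
- compound 3 `c1ccc(COc2cccc(Nc3ncnc4cc5c(cc34)OCCOCCOCCO5)c2)cc1`: 22800 nM

All three compounds share the same core and differ only in the benzyloxy arm. In a functional assay on SH-SY5Y cells (Homo sapiens) for antiproliferative activity, read by MTT assay, with a stated time of 72 h (on this read-out lower numbers stand for stronger inhibition and higher numbers for weaker inhibition), compound 1 gives 23900 nM, compound 2 gives 20000 nM and compound 3 gives 22800 nM. Compound 3 stands second highest of the three numbers, but its gaps to compound 1 and to compound 2 are both within the scatter, so no order among the three can be claimed.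

Compound 4 `O=[N+]([O-])c1ccc(COc2cccc(Nc3ncnc4cc5c(cc34)OCCOCCOCCO5)c2)cc1` is not yet measured. The change from compound 3 is nitro in place of hydrogen on an aromatic carbon. For the measured compounds named here, the one measured step that bears on it, a 1.1-fold higher number from compound 2 to compound 3 (0.06 log units; within the scatter), also swaps a substituent on that aromatic carbon and moved nothing beyond the scatter. Nothing in the series shows a substituent on the benzyl ring shifting the number in this assay.

Compound 4 is therefore expected to come out near compound 3, with a step of a 1.1-fold lower number from compound 3 to compound 4 (0.04 log units; within the scatter) in this assay that stays within the scatter. The estimate for compound 4 is 21000 nM, expected to lie between 9000 nM and 50000 nM.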

Compound 4, half-maximal inhibitory concentration: > 100000 nM
Compound 4: no number, only a limit; the forecaster's own chance of this, stated with the estimate: 10%; middle value at least 4.7-fold (0.67 log units) away from the limit.
By their numbers in this assay, from the lowest: compounds 2, 3 and 1 (each within the scatter of the next). At a limit, above all of these: compound 4.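

Compound 4 carries only a limit of the assay in this assay: the limit of > 100000 nM in this assay, at which 1 of the 4 values shown sits. Nitro on the aromatic carbon para to a large group gives an at least 4.3-fold higher number from compound 3 to compound 4 (0.64 log units; beyond the scatter), and set against trifluoromethyl on that same carbon it gives an at least 5.0-fold higher number from compound 2 to compound 4 (0.69 log units; beyond the scatter). This carbon is therefore not indifferent to what it carries, even though trifluoromethyl and hydrogen there do not separate, with a 1.1-fold higher number from compound 2 to compound 3 (0.06 log units; within the scatter); the two nitro steps give only a minimum size, since one end of each is a limit.

The compounds shown leave open whether this shift belongs to nitro alone or would also come with an amine, a nitrile or a carboxylic acid on the same carbon. From the compounds shown here alone, how far the true value of compound 4 lies past its limit also stays open.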